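Swapping the amine substituent in a tryptamine-derived series

This account rests on a few compounds, and the source may have more. Where it says the series, first, only, none or still open, it means among the compounds named here.

Measured compounds:
compound 1 `O=S(=O)(NCC1CCN(CCCc2c[nH]c3ccc(-n4cnnc4)cc23)CC1)c1ccccc1` — 12 nM
compound 2 `COC[C@H](NC1CCN(CCCc2c[nH]c3ccc(Cn4cncn4)cc23)CC1)c1ccc(F)cc1` — 8.9 nM
compound 3 `CC(=O)Nc1ccc([C@H](C)NCC2CCN(CCCc3c[nH]c4ccc(-n5cnnc5)cc34)CC2)cc1` — 3 nM

All three were tested in an assay on CHO cells for agonist activity at 5-hydroxytryptamine receptor 1D (Homo sapiens), read by GTPgammaS binding; on this read-out lower numbers stand for an effect already at smaller amounts and higher numbers for an effect only at larger amounts of compound. Compound 3 gives the lowest number of the three, with compound 2 nearest and compound 1 furthest away; both gaps are beyond the scatter. Compound 2 differs from compound 3 in more than one place, so only its value can be set beside that of compound 3.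

Compound 4 `c1ccc2c(c1)CCC2NCC1CCN(CCCc2c[nH]c3ccc(-n4cnnc4)cc23)CC1` has not yet been measured. It differs from compound 3 in one place: 2,3-dihydro-1H-inden-1-yl in place of 1-(4-acetamidophenyl)ethyl on an amine nitrogen. The new group carries no hydrogen-bond donor or acceptor, which the leaving group did.

Going by the values given here, one measured step bears on this change, since it also alters the group on the same amine nitrogen: a 4.0-fold lower number from compound 1 to compound 3 (0.60 log units; beyond the scatter). That step ran from a group without the acetamidophenyl part to one with it, and the number fell. Undoing that part while keeping a carbon ring system suggests the number is expected to move back upward by a modest step, a 2.7-fold higher number from compound 3 to compound 4 (0.43 log units; beyond the scatter), though it may stay within the scatter.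

Compound 4 is therefore estimated at 8 nM, with a likely range from 3 nM to 25 nM.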

Compound 4, half-maximal effective concentration: 1.3 nM
Compound 4: the middle estimate sits 6.2-fold (0.79 log units) above what was measured, and the stated range ends above it.
By their numbers in this assay, from the lowest: compound 4; then compound 3; then compounds 2 and 1 (each within the scatter of the next).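

In this assay, putting 2,3-dihydro-1H-inden-1-yl in place of 1-(4-acetamidophenyl)ethyl on the amine nitrogen gives a 2.3-fold lower number from compound 3 to compound 4 (0.36 log units; beyond the scatter), so a group with 0 hydrogen-bond donors and 0 hydrogen-bond acceptors serves here at least as well as one that carries both. Measured against the sulfonamide, the same group gives a 9.2-fold lower number from compound 1 to compound 4 (0.97 log units; beyond the scatter), which shows that a low number at this position does not depend on the acetamide part that compound 3 carries. Nothing available here explains why the number falls with this change.

The change removes the acetamide part, closes a five-membered non-aromatic ring and loses the defined stereocentre all at once, and the compounds shown cannot separate these three differences. A plain 1-phenylethyl group on the same amine nitrogen would sit between compound 3 and compound 4 in structure and could show whether removing the acetamide or closing the ring accounts for more of the step, while the two separate mirror-image forms of the 2,3-dihydro-1H-inden-1-yl compound remain an open comparison.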